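Vinyl in place of bromo: expected cytotoxicity of compound 3

A few compounds are considered here, and "the series" means these few. Any claim that something is new, unique, unknown or untested is made for them only; others in the source may bear on it.

Compound 2 `Cc1ncnc2c1c(Br)cn2[C@@H]1C=C(CO)[C@@H](O)[C@H]1O` carries a bromo group on the shared core. In an ADME assay on Huh-7 cells (Homo sapiens) for cytotoxicity (on this read-out higher numbers stand for lower toxicity in this test and lower numbers for higher toxicity in this test), compound 2 gives > 100000 nM, which is a limit of the assay rather than a number. Compound 1 `Cc1ncnc2c1c(F)cn2[C@@H]1C=C(CO)[C@@H](O)[C@H]1O` carries fluoro at the same place. In this assay compound 1 gives > 100000 nM, again a limit rather than a number. The step that the two limits leave unreadable from compound 1 to compound 2 therefore cannot be read; what is known is the limit of > 100000 nM in this assay, at which 2 of the 2 values shown sit. Compound 3 `C=Cc1cn([C@@H]2C=C(CO)[C@@H](O)[C@H]2O)c2ncnc(C)c12` is not yet measured; it differs from compound 2 by vinyl in place of bromo on an aromatic carbon. Among the measured compounds shown here, no measured step bears on this change, since the only measured step is unreadable. Nothing beyond the scatter is expected in this assay, and the expected step is a number no higher from compound 2 to compound 3 (the limit leaves the size open). Compound 3 is expected to give 100000 nM, in a range from 30000 nM to 300000 nM, most likely again as a limit.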

Compound 3, half-maximal cytotoxic concentration: 52800 nM
Compound 3: the middle estimate sits 1.9-fold (0.28 log units) above what was measured; the measured number falls inside the stated range.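

Among the compounds shown here, compound 3 is the only compound here that gives a number rather than a limit in this assay, so a change at this aromatic carbon can yield a readable value in this test. Vinyl gives an at least 1.8-fold lower number from compound 2 to compound 3 (0.27 log units; that floor lies within the scatter) when it replaces bromo, and an at least 1.8-fold lower number from compound 1 to compound 3 (0.27 log units; that floor lies within the scatter) when it replaces fluoro, so neither step shows a real change, though the true size of each may be larger than its floor. The step between the two halogen compounds cannot be read, and both steps to vinyl are only floors: the limit of > 100000 nM in this assay, at which 2 of the 3 values shown sit.

Going by these compounds, it remains open whether a carbon group at this place truly gives a lower number than a halogen does. Nor do the compounds shown tell how an ethyl group, a longer chain or an amine on this same carbon would read out.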